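The source may hold more compounds than are shown below. What is called first, only, known or untested is meant among the compounds shown, and "the series" means these compounds.

Measured in a functional assay on K562 cells (Homo sapiens) for antiproliferative activity, read by CellTiter-Glo, with a stated time of 72 h; on this read-out lower numbers stand for an effect already at smaller amounts and higher numbers for an effect only at larger amounts of compound:
- Compound 1 `CCCCCCCNc1ncnc2c1ncn2[C@@H]1O[C@H](COS(N)(=O)=O)[C@@H](O)[C@H]1O`: 132 nM
- Compound 2 `CC(C)(C)CC(C)(C)Nc1ncnc2c1ncn2[C@@H]1O[C@H](COS(N)(=O)=O)[C@@H](O)[C@H]1O`: > 1000 nM (a limit)

Compound 2 has no exact number and stands at the limit of > 1000 nM in this assay, at which 1 of the 2 values shown sits. Compound 3 `CCCCCC(C)Nc1ncnc2c1ncn2[C@@H]1O[C@H](COS(N)(=O)=O)[C@@H](O)[C@H]1O` differs from it by one change, (1-methylhexyl in place of 1,1,3,3-tetramethylbutyl on a nitrogen on an aromatic ring), with 1-methylhexyl in place of 1,1,3,3-tetramethylbutyl on a nitrogen on an aromatic ring. Within the data shown here, the only measured step that bears on this is an at least 7.5-fold higher number from compound 1 to compound 2 (0.87 log units; beyond the scatter). Going by that step, a partial return towards compound 1 is expected, meaning a lower number in this assay. The expected change is an at least 3.1-fold lower number from compound 2 to compound 3 (0.49 log units; beyond the scatter). The estimate for compound 3 is 320 nM, with an expected range from 110 nM to 1000 nM.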

Compound 3, half-maximal effective concentration: 203 nM
Compound 3: the middle estimate sits 1.6-fold (0.20 log units) above what was measured; the measured number falls inside the stated range.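

Compound 2 carries only a limit, > 1000 nM, and not an exact number. Even so, an at least 4.9-fold lower number from compound 2 to compound 3 (0.69 log units; beyond the scatter) shows that the loss seen with 1,1,3,3-tetramethylbutyl does not extend to every branched chain on this nitrogen. Against the straight heptyl chain, 1-methylhexyl gives a 1.5-fold higher number from compound 1 to compound 3 (0.19 log units; within the scatter), so these two groups cannot be told apart on this read-out.

Which part of 1,1,3,3-tetramethylbutyl accounts for its loss remains open. So does how a longer chain such as decyl, or a chain ending in an amine or a carboxylic acid, would fare on this nitrogen.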